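This account rests on a few compounds, and the source may have more. Where it says the series, first, only, none or still open, it means among the compounds named here.

Three measured compounds share one core. Compound 1 `O=S(=O)(c1cnc2ccccc2c1)n1cc(C2=CCNCC2)c2ccccc21` gives 13 nM in an assay on HEK293 cells for displacement of a labelled ligand from 5-hydroxytryptamine receptor 6 (Homo sapiens), read by scintillation counting; on this read-out lower numbers stand for stronger inhibition and higher numbers for weaker inhibition. Compound 2 `O=S(=O)(c1cc2ccccc2cn1)n1cc(C2=CCNCC2)c2ccccc21` gives 12 nM in this assay. Compound 3 `O=S(=O)(c1cnc2ccccc2c1)n1cc(C2=CCNCC2)c2cc(Cl)ccc21` gives 11 nM in this assay; this is the lowest of the three numbers, yet its gaps to compound 2 and to compound 1 both lie within the scatter, so no order among the three can be stated. Within the data shown here, the only single-point step measured so far, a 1.2-fold lower number from compound 1 to compound 3 (0.07 log units; within the scatter), places chloro in place of hydrogen on an aromatic carbon without moving the number beyond the scatter.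

Compound 4 `COc1ccc2c(c1)c(C1=CCNCC1)cn2S(=O)(=O)c1cnc2ccccc2c1` is not yet measured. It differs from compound 3 in one place: methoxy in place of chloro on an aromatic carbon. Among the measured compounds shown here, only the step from compound 1 to compound 3 bears on this aromatic carbon, and it stayed within the scatter. A second swap at that aromatic carbon is therefore expected to do little; in this assay the expected step is a 1.4-fold higher number from compound 3 to compound 4 (0.13 log units; within the scatter). For compound 4 the estimate in this assay is 15 nM, with a range of 6 nM to 40 nM.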

Compound 4, inhibition constant: 8 nM
The estimate for compound 4 lay 1.9-fold (0.27 log units) above the measured number, and the stated range covers the measured number.
By their numbers in this assay, from the lowest: compounds 4, 3, 2 and 1 (each within the scatter of the next).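

At this aromatic carbon of the shared core, this assay now covers three groups, with a 1.4-fold lower number from compound 3 to compound 4 (0.14 log units; within the scatter) and a 1.6-fold lower number from compound 1 to compound 4 (0.21 log units; within the scatter) as the two new steps. Methoxy brings a hydrogen-bond acceptor that chloro lacks, yet hydrogen, chloro and methoxy at this carbon still cannot be ordered, so the change of group type has not moved the number beyond the scatter. Nothing at hand accounts for this flat response.

Still open, going by these compounds, is whether an amine, a carboxylic acid or a longer alkoxy chain at this aromatic carbon would move the number beyond the scatter. Also open, on these data alone, is whether methoxy or chloro at this carbon would give the same flat result on the core of compound 2.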